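A few compounds are considered here, and "the series" means these few. Any claim that something is new, unique, unknown or untested is made for them only; others in the source may bear on it.

Measured in an ADME assay on HepG2 cells (Homo sapiens) for cytotoxicity, read by luminescence, CellTiter-Glo and ATP content, with a stated time of 72 h; on this read-out lower numbers stand for an effect already at smaller amounts and higher numbers for an effect only at larger amounts of compound:
- compound 1 `CCC(CC)c1ccc2c(NCCCNCc3cc(F)ccc3OC)ccnc2c1`: 7860 nM
- compound 2 `COc1ccc(F)cc1CNCCCNc1ccnc2cc(-c3ccc(F)cc3)ccc12`: 770 nM
- compound 3 `COc1ccc(F)cc1CNCCCNc1ccnc2cc(Oc3ccccc3)ccc12`: 1500 nM

Compound 3 holds the second highest of the three numbers in this assay. Its nearest neighbour is compound 2, the gap a 1.9-fold higher number from compound 2 to compound 3 (0.29 log units; within the scatter) lying within the scatter, so the two are not separated; the furthest is compound 1, with a 5.2-fold lower number from compound 1 to compound 3 (0.72 log units; beyond the scatter) beyond the scatter.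

The step to compound 4 `COc1ccc(F)cc1CNCCCNc1ccnc2cc(-c3cccc4ccccc34)ccc12` is naphthalen-1-yl in place of phenoxy on an aromatic carbon.

Among the measured compounds shown here, two measured steps bear on this position. a 10-fold lower number from compound 1 to compound 2 (1.01 log units; beyond the scatter) and a 5.2-fold lower number from compound 1 to compound 3 (0.72 log units; beyond the scatter) both show that an aromatic substituent in place of pentan-3-yl gives a clearly lower number, while a 1.9-fold higher number from compound 2 to compound 3 (0.29 log units; within the scatter) shows that exchanging one aromatic substituent for another leaves the number within the scatter. For the measured compounds named here, no measured step replaces a single aromatic ring by a fused pair of rings, so the size of the present step is not directly anchored. The expectation for this assay is therefore a step of a 1.7-fold lower number from compound 3 to compound 4 (0.22 log units; within the scatter) toward a lower number, small and possibly not beyond the scatter, since compound 4 keeps an aromatic group at the same place.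

Compound 4 is estimated at 900 nM, in the range 300 nM to 3000 nM.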

Compound 4, half-maximal effective concentration: 16000 nM
Beside the measured number, compound 4's estimate is 18-fold (1.25 log units) below it; measured number above the stated range.
By their numbers in this assay, from the lowest: compounds 2 and 3 (each within the scatter of the next); then compound 1; then compound 4.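

In this assay, this position does not treat all aromatic substituents alike: naphthalen-1-yl in place of phenoxy gives a large rise (an 11-fold higher number from compound 3 to compound 4 (1.03 log units; beyond the scatter)), and naphthalen-1-yl in place of 4-fluorophenyl gives a larger one on the printed numbers (a 21-fold higher number from compound 2 to compound 4 (1.32 log units; beyond the scatter)), whereas the earlier exchange between phenoxy and 4-fluorophenyl stayed within the scatter. Measured against pentan-3-yl, naphthalen-1-yl moves the number the opposite way to the other two aromatic groups (a 2.0-fold higher number from compound 1 to compound 4 (0.31 log units; beyond the scatter)). The lower number with an aromatic group in place of pentan-3-yl therefore holds for compound 2 and compound 3, compound 4 goes against it, and nothing at hand explains the reversal.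

Open, going by these compounds, is whether the rise follows the second fused aromatic ring or the way the ring system is attached, a question that naphthalen-2-yl at the same aromatic carbon could address. Also open, on these data alone, is whether a basic amine or a carboxylic acid on a single phenyl ring at this place would stay near compound 2 and compound 3 or move toward compound 4.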